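Swapping the Nitro Group for a Methoxy Group

This account rests on a few compounds, and the source may have more. Where it says the series, first, only, none or still open, it means among the compounds named here.

Two compounds share a common core. Compound 1 `COc1cccc(OC)c1OCCNCCOc1ccccc1OCc1cccc([N+](=O)[O-])c1` and compound 2 `COc1cccc(OC)c1OCCNCCOc1ccccc1OCc1ccc([N+](=O)[O-])cc1` were tested in a functional assay on PC-3 cells (Homo sapiens) for cytotoxicity, read by sulforhodamine B assay; a lower number here means a stronger inhibitor of growth, a higher number a weaker inhibitor of growth. In this assay compound 1 gives 38900 nM, and in this assay compound 2 gives 43600 nM. Among the compounds with values here, compound 2 stands beside compound 1 as one of only two measured numbers, and the step of a 1.1-fold higher number from compound 1 to compound 2 (0.05 log units; within the scatter) does not separate them beyond the scatter. Compound 3 `COc1ccccc1COc1ccccc1OCCNCCOc1c(OC)cccc1OC` has not yet been measured; it differs from compound 2 by 2-methoxyphenyl in place of 4-nitrophenyl on a saturated chain carbon bound to an oxygen on an aromatic ring. Within the data shown here, no measured step involves a methoxy group or the removal of a nitro group, so the only guide is that moving the nitro group from one position to another, a 1.1-fold higher number from compound 1 to compound 2 (0.05 log units; within the scatter), changed little. With that weak guide the expected step of a 1.1-fold lower number from compound 2 to compound 3 (0.04 log units; within the scatter) is small, with a wide range in either direction. Compound 3 is therefore estimated at 40000 nM, between 15000 nM and 100000 nM.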

Compound 3, concentration for total growth inhibition: 30200 nM
Compound 3: middle estimate off by 1.3-fold (0.12 log units), on the high side; low and high end bracket the measured number.
By their numbers in this assay, from the lowest: compounds 3, 1 and 2 (each within the scatter of the next).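

Putting 2-methoxyphenyl in place of a nitrophenyl group, on a saturated chain carbon bound to an oxygen on an aromatic ring, gives in this assay a 1.4-fold lower number from compound 2 to compound 3 (0.16 log units; within the scatter) and a 1.3-fold lower number from compound 1 to compound 3 (0.11 log units; within the scatter). The earlier pair only moved the nitro group, whereas these steps show that the nitro group can be absent and a methoxy group present on this ring with no step beyond the scatter. No supporting measurement is available to explain this result.

The compounds shown leave open whether 4-methoxyphenyl, or a ring carrying an amine or a carboxylic acid, would also stay within the scatter of these three. They also leave open whether a longer chain at this place, or a change elsewhere in the shared core, would give a step beyond the scatter.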